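The compounds below may be only part of what the source reports. "The series", "measured", "known", "first", "only" and "open" are said of these compounds alone.

Measured in a functional assay on MCF7 cells (Homo sapiens) for cytotoxicity, read by sulforhodamine B assay, with a stated time of 3 days; a lower number here means a stronger inhibitor, a higher number a weaker inhibitor:

- Compound 1 `Nc1ccccc1S(=O)(=O)N1CC(n2cnc3c(Cl)nc(Cl)nc32)OCc2ccccc21`: 820 nM
- Compound 2 `O=[N+]([O-])c1ccccc1S(=O)(=O)N1CC(n2cnc3nc(Cl)nc(Cl)c32)OCc2ccccc21`: 990 nM
- Compound 3 `c1ccc(Sc2nc(Sc3ccccc3)c3ncn(C4CNc5ccccc5CO4)c3n2)cc1`: 9710 nM

Compound 1 and compound 2 sit level, as their two numbers lie within the usual scatter of repeated measurements. Compound 3 stands apart, with a number higher than that of compound 1 by more than the scatter.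

The next compound to be tested is compound 4 `O=[N+]([O-])c1ccc(S(=O)(=O)N2CC(n3cnc4c(Cl)nc(Cl)nc43)OCc3ccccc32)cc1`, which keeps the core of compound 1 and changes one group: 4-nitrophenyl in place of 2-aminophenyl on a sulfonyl sulfur.

Going by the values given here, no measured pair shows this swap directly, so any forecast is loose. The closest guide is compound 2, which also has a nitrophenyl on a sulfonyl sulfur and gives 990 nM in line with compound 1. In this assay no shift beyond the scatter is therefore expected, and the estimated step is a 1.2-fold higher number from compound 1 to compound 4 (0.09 log units; within the scatter) for this swap.

For compound 4 the expected value is 1000 nM, with an estimated range from 350 nM to 3000 nM as its likely span.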

Compound 4, half-maximal inhibitory concentration: 355 nM
The estimate for compound 4 lay 2.8-fold (0.45 log units) above the measured number; measured number inside the range.
By their numbers in this assay, from the lowest: compound 4; then compounds 1 and 2 (each within the scatter of the next); then compound 3.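

In this assay, the group on the sulfonyl sulfur can move the number: placing 4-nitrophenyl where 2-aminophenyl stood gives a 2.3-fold lower number from compound 1 to compound 4 (0.36 log units; beyond the scatter), a modest step, and the first in this set that can be read at a single place. Both the group on the ring and where it sits change at once, so this one pair cannot separate the two. Nothing measured on these compounds accounts for the step.

Still open, from the compounds shown here alone, is whether a 4-aminophenyl on the same sulfur, which would keep the amine and change only where it sits, would give a number closer to that of compound 1 or compound 4. An unsubstituted phenyl or a small methyl group there would show how much of the aromatic ring and its substituent the number depends on.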